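The source may report more compounds than this note shows. Statements on the series, on what has been measured and on what is new or still open speak of the compounds shown alone.

Measured in a functional assay on HepG2 cells (Homo sapiens) for inhibition, read by MTT assay, with a stated time of 48 h; on this read-out higher numbers stand for weaker inhibition of growth and lower numbers for stronger inhibition of growth:
- compound 1 `Cn1cc(C2CC(c3ccccc3)=NN2C(=O)c2cccnc2)c2ccccc21`: 4630 nM
- compound 2 `Cn1cc(C2CC(c3ccccc3)=NN2C(=O)c2ccc(Cl)nc2)c2ccccc21`: 7910 nM
- compound 3 `Cn1cc(C2CC(c3ccccc3)=NN2C(=O)c2cccnc2)c2cc(Br)ccc21`: 2520 nM

Compound 1 at 4630 nM and compound 3 at 2520 nM lie within the scatter of each other. Compound 2 at 7910 nM and compound 3 at 2520 nM lie further apart, beyond the scatter, with the lower number on compound 3.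

The next compound is compound 4 `COc1cc(C2=NN(C(=O)c3cccnc3)C(c3cn(C)c4ccc(Br)cc34)C2)cc(OC)c1OC`. It keeps the core of compound 3 and carries 3,4,5-trimethoxyphenyl in place of phenyl on a carbon with a double bond to nitrogen.

Within the data shown here, only two measured steps are available. Chloro in place of hydrogen on an aromatic carbon gives a 1.7-fold higher number from compound 1 to compound 2 (0.23 log units; within the scatter), and bromo in place of hydrogen on an aromatic carbon gives a 1.8-fold lower number from compound 1 to compound 3 (0.26 log units; within the scatter). Both stay within the scatter, and neither touches the phenyl group, so they bear on this change only indirectly. Going by these compounds, the series holds no measured change at this place, and the direction in this assay remains open. The anchor for the expectation is therefore compound 3 at 2520 nM, with a wide range.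

The estimated change is a 1.3-fold lower number from compound 3 to compound 4 (0.10 log units; within the scatter), so no step beyond the scatter is expected. For compound 4 the expected value is 2000 nM, with an estimated range from 500 nM to 8000 nM.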

Compound 4, concentration for 50% growth inhibition: > 10000 nM
Compound 4: a limit, no number (the forecaster's own chance of this, stated with the estimate: 5%); middle value at least 5.0-fold (0.69 log units) from the limit.
By their numbers in this assay, from the lowest: compounds 3, 1 and 2 (each within the scatter of the next, the first and the last beyond it). At a limit, above all of these: compound 4.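

In this assay compound 4 gives > 10000 nM, which is a limit of the assay and not a number. Among these compounds, this is the only measured change at the carbon with a double bond to nitrogen, and it reads as an at least 3.9-fold higher number from compound 3 to compound 4 (0.59 log units; beyond the scatter), so 3,4,5-trimethoxyphenyl in place of phenyl at this place weakens growth inhibition on the core of compound 3, by a step beyond the scatter, whereas the earlier single-place steps, both made elsewhere on the molecule, stayed within it. The size of this step is bounded from one side only, so the data fix its direction but not its full extent: the limit of > 10000 nM in this assay, at which 1 of the 4 values shown sits.

What the compounds shown leave open is whether a single methoxy group on the phenyl, or a different group such as an amine or a carboxylic acid at the same place, would give the same direction as the 3,4,5-trimethoxyphenyl group. Also open, going by these compounds, is whether the same exchange on the core of compound 1, which lacks the bromo group, moves the number in this assay in the same way.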